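The source may hold more compounds than are shown below. What is called first, only, known or untested is meant among the compounds shown, and "the series" means these compounds.

Measured in an ADME assay on MCF-10A cells (Homo sapiens) for cytotoxicity, read by CCK-8 assay and cell counting, with a stated time of 72 h; on this read-out higher numbers stand for weaker inhibition and lower numbers for stronger inhibition:
compound 1 `COc1ccc(-c2cc3ccccc3c(-c3ccc(O)cc3)n2)cc1` — > 50000 nM
compound 2 `COc1cc(OC)cc(-c2cc3ccccc3c(-c3ccc(O)cc3)n2)c1` — 7280 nM
compound 3 `COc1cccc(-c2nc(-c3ccc(OC)c(OC)c3)cc3cc(C)ccc23)c1` — > 50000 nM

Compound 3 gives only a limit in this assay, not a number. Compound 1 also sits at a limit there, which is the limit of > 50000 nM in this assay, at which 2 of the 3 values shown sit. Within the data shown here, compound 2 is the one measured compound with a number. Compound 4 `COc1ccc(-c2cc3cc(C)ccc3c(-c3ccc(O)cc3)n2)cc1OC` is not yet measured; it differs from compound 3 by 4-hydroxyphenyl in place of 3-methoxyphenyl on an aromatic carbon. Compound 1 and compound 2 both carry a 4-hydroxyphenyl, yet one sits at the limit and the other does not, so the change gives no clear direction. The step of an at least 1.4-fold lower number from compound 3 to compound 4 (0.15 log units; that floor lies within the scatter) is expected to be small, if any, and may again end at a limit. Compound 4 is estimated at 35000 nM, with a range from 8000 nM to 100000 nM.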

Compound 4, half-maximal inhibitory concentration: 18100 nM
Estimate against measurement, compound 4: 1.9-fold (0.29 log units) above; the range from low to high includes it.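

In this assay, among these compounds, the first single-place comparison shows that 4-hydroxyphenyl in place of 3-methoxyphenyl on this aromatic carbon, next to the ring nitrogen, gives an at least 2.7-fold lower number from compound 3 to compound 4 (0.44 log units; beyond the scatter). That step is only a floor, since compound 3 stands at a limit: the limit of > 50000 nM in this assay, at which 2 of the 4 values shown sit.

Compound 1 also carries 4-hydroxyphenyl, yet its > 50000 nM is a limit too, so this group does not yield a measured number in every compound.

Which part of the swap carries the step stays open. Also open, on these data alone, is whether an amine or a carboxylic acid in place of the hydroxyl would lower the number further.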